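Working notes: removing the methoxy side chain toward compound 4

This account rests on a few compounds, and the source may have more. Where it says the series, first, only, none or still open, it means among the compounds named here.

Of the compounds shown here, three have been measured in a functional assay on MDA-MB-436 cells (Homo sapiens) for antiproliferative activity, read by MTT assay, with a stated time of 48 h; on this read-out lower numbers stand for stronger inhibition and higher numbers for weaker inhibition. Compound 1 `C=CS(=O)(=O)N1CCN(c2ncnc3sc(-c4ccc(C#N)cc4)cc23)CC1` gives 9170 nM in this assay. Compound 2 `C=CS(=O)(=O)N1CCN(c2nc(OC[C@H]3CCCN3C)nc3sc(-c4ccc(C#N)cc4)cc23)CC1`, which carries the (1-methylpyrrolidin-2-yl)methoxy group, gives 2290 nM. Compound 3 `C=CS(=O)(=O)N1CCN(c2nc(OC[C@H]3CCCN3C)nc3sc(-c4ccc(N5CCN(C)CC5)cc4)cc23)[C@@H](C)C1` gives 1920 nM. The difference between the cores of compound 2 and compound 3 is not broken down here, and the values of compound 3 and compound 2 lie within the scatter of each other.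

Within the data shown here, the one counted step is hydrogen in place of (1-methylpyrrolidin-2-yl)methoxy on an aromatic carbon, which gave a 4.0-fold higher number from compound 2 to compound 1 (0.60 log units; beyond the scatter).

Compound 4 `C=CS(=O)(=O)N1CCN(c2ncnc3sc(-c4ccc(N5CCN(C)CC5)cc4)cc23)[C@@H](C)C1` has not been measured. Its relation to compound 3 is hydrogen in place of (1-methylpyrrolidin-2-yl)methoxy on an aromatic carbon. Among the measured compounds shown here, this is the same kind of change as the one from compound 2 to compound 1, not the same change: in compound 3 the place is meta to a 2-methyl-4-(vinylsulfonyl)piperazin-1-yl group, whereas in compound 2 it is meta to a 4-(vinylsulfonyl)piperazin-1-yl group; the remainder of the surroundings agree. The change occurs twice among these compounds, once measured.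

For the measured compounds named here, for compound 4 a step of about the same size is expected, a 4.0-fold higher number from compound 3 to compound 4 (0.60 log units; beyond the scatter), because a 4.0-fold higher number from compound 2 to compound 1 (0.60 log units; beyond the scatter) is the only measured precedent. Compound 4 is accordingly estimated at 7700 nM in this assay. For compound 4 the expected range is estimated to run from 3500 nM to 17000 nM, wide since a single precedent on a differing core is all that supports it.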

Compound 4, half-maximal inhibitory concentration: 6920 nM
Compound 4: the middle estimate sits 1.1-fold (0.05 log units) above what was measured, within the range that was stated.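

In this assay, replacing the (1-methylpyrrolidin-2-yl)methoxy group with hydrogen gives a 3.6-fold higher number from compound 3 to compound 4 (0.56 log units; beyond the scatter), and this step agrees with the earlier one: the same change on two cores in this assay, a 4.0-fold higher number (0.60 log units; beyond the scatter) from compound 2 to compound 1 and a 3.6-fold higher number (0.56 log units; beyond the scatter) from compound 3 to compound 4, 1.1-fold (0.05 log units) apart, within the scatter of two such steps In these two pairs, the size of the step therefore carries over from the core of compound 2 to the core of compound 3, even though the cores differ both in the 2-methyl-4-(vinylsulfonyl)piperazin-1-yl group and in the substituent on the far aryl ring. This does not show that the step would hold on other cores or in other assays, and the two pairs cannot separate the contributions of the core differences or explain why the side chain changes the read-out.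

Still open, as far as these compounds go, is how much of the step belongs to the whole (1-methylpyrrolidin-2-yl)methoxy group, and whether a plain methoxy, an open-chain 2-(dimethylamino)ethoxy or an amine attached directly at the same ring carbon, between the two ring nitrogen atoms, would give a similar result. The compounds shown also leave open whether the defined stereocentre of the side chain matters, since its opposite enantiomer does not appear among them.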